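The source may report more compounds than this note shows. Statements on the series, on what has been measured and on what is new or still open speak of the compounds shown alone.

Compound 1 `Cc1cc2c(cc1Cl)N(Cc1cn(Cc3ccccc3)nn1)C(=O)CO2`: 19600 nM
Compound 2 `Cc1ccc2c(c1)N(Cc1cn(Cc3ccccc3)nn1)C(=O)CO2`: > 100000 nM

Both results come from a functional assay on HT-29 cells (Homo sapiens) for cytotoxicity, read by MTT assay, with a stated time of 6 days; on this read-out lower numbers stand for stronger inhibition and higher numbers for weaker inhibition. Compound 2 has no exact number, as its > 100000 nM is only a limit of the assay. Compound 3 `O=C1COc2ccc(Cl)cc2N1Cc1cn(Cc2ccccc2)nn1` has chloro in place of methyl on an aromatic carbon. Compound 1 carries chloro as well as methyl and gives 19600 nM, so a moderate step towards stronger inhibition is expected in this assay. The expected change is an at least 2.5-fold lower number from compound 2 to compound 3 (0.39 log units; beyond the scatter). Compound 3 is estimated at 40000 nM, with an expected range of 15000 nM to 100000 nM.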

Compound 3, half-maximal inhibitory concentration: 76500 nM
Compound 3: the middle estimate sits 1.9-fold (0.28 log units) below what was measured; the measured number falls inside the stated range.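

In this assay, chloro in place of methyl on an aromatic carbon gives an at least 1.3-fold lower number from compound 2 to compound 3 (0.11 log units; that floor lies within the scatter). The size of this change stays unknown because one end of the comparison is only a limit: the limit of > 100000 nM in this assay, at which 1 of the 3 values shown sits.

With chloro already present, removing the methyl gives a 3.9-fold higher number from compound 1 to compound 3 (0.59 log units; beyond the scatter), so the methyl still counts when the two groups sit together, which compound 2 alone could not reveal.

Open, from the compounds shown here alone, is how other groups would behave at this position, such as an amine or a methoxy group. Whether bromo would act like chloro also remains unanswered.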